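The source may report more compounds than this note shows. Statements on the series, on what has been measured and on what is new or still open speak of the compounds shown alone.

Going by the values given here, in a functional assay on K562 cells (Homo sapiens) for inhibition, read by MTT assay, with a stated time of 48 h (a lower number here means a stronger inhibitor, a higher number a weaker inhibitor), two compounds have numbers so far. Compound 1 (`CS(=O)(=O)Nc1ccc(-c2cn([C@@H]3CN[C@H](C(=O)Nc4ccc(Cl)c(C(F)(F)F)c4)C3)nn2)cn1`) gives 5060 nM in this measurement, while compound 2 (`CC(C)(C)OC(=O)N1C[C@@H](n2cc(-c3ccc4c(N)n[nH]c4c3)nn2)C[C@H]1C(=O)Nc1ccc(Cl)c(C(F)(F)F)c1`) gives 10500 nM and holds the higher of the two numbers, making it the weaker inhibitor of the pair by a margin beyond the usual scatter. Compound 3 (`Nc1n[nH]c2cc(-c3cn([C@@H]4CN[C@H](C(=O)Nc5ccc(Cl)c(C(F)(F)F)c5)C4)nn3)ccc12`) is still unmeasured. It departs from compound 2 in one place (hydrogen in place of tert-butoxycarbonyl on an amine nitrogen in a ring), with hydrogen in place of tert-butoxycarbonyl on an amine nitrogen in a ring. Among the compounds with values here, no measured pair isolates this change, so the expectation rests on thin ground. Compound 1 also bears hydrogen on that nitrogen and sits at 5060 nM in this comparison, which points to a moderate gain. The expected change is a 2.1-fold lower number from compound 2 to compound 3 (0.32 log units; beyond the scatter) toward a lower number. For compound 3 the estimated value is 5000 nM with an expected range from 1800 nM to 14000 nM in this assay.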

Compound 3, half-maximal inhibitory concentration: 8320 nM
For compound 3 the middle estimate is 1.7-fold (0.22 log units) below the measured one, within the range that was stated.
By their numbers in this assay, from the lowest: compounds 1, 3 and 2 (each within the scatter of the next, the first and the last beyond it).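

In this assay the group on the ring amine nitrogen turns out to carry little weight: hydrogen in place of tert-butoxycarbonyl gives a 1.3-fold lower number from compound 2 to compound 3 (0.10 log units; within the scatter), so a group of that size can leave this position without a readable change. With hydrogen on that nitrogen, 3-amino-1H-indazol-6-yl in place of 6-(methanesulfonamido)pyridin-3-yl gives a 1.6-fold higher number from compound 1 to compound 3 (0.22 log units; within the scatter), so this exchange on the aromatic carbon also stays within the scatter. No measurement at hand accounts for either result.

The compounds shown leave open whether a methyl or an acetyl group on that ring nitrogen would move the number beyond the scatter. They also leave open whether a carboxylic acid or a primary amine on the aromatic group would do so.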